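The compounds below may be only part of what the source reports. "The series", "measured", "known", "first", "only" and "open" are said of these compounds alone.

Compound 1, `COc1ccc(/C=N/NC(=O)Nc2ccc(Oc3ccnc4cc(OCCCN5CCCCC5)c(OC)cc34)c(F)c2)cc1`, in a functional assay on HT-29 cells (Homo sapiens) for cytotoxicity, read by MTT assay, with a stated time of 72 h (on this read-out lower numbers stand for stronger inhibition and higher numbers for weaker inhibition), gives 590 nM.
Compound 2, `COc1cc2c(Oc3ccc(NC(=O)N/N=C/c4ccc(C(F)(F)F)cc4)cc3F)ccnc2cc1OCCCN1CCCCC1`, in this assay gives 660 nM.
Compound 3, `COc1cc2c(Oc3ccc(NC(=O)N/N=C/c4ccc(F)cc4Cl)cc3F)ccnc2cc1OCCCN1CCCCC1`, in this assay gives 260 nM.

Compound 3 holds the lowest number of the three. The steps of a 2.3-fold lower number from compound 1 to compound 3 (0.36 log units; beyond the scatter) and a 2.5-fold lower number from compound 2 to compound 3 (0.40 log units; beyond the scatter) both lie beyond the scatter, so compound 3 stands as the most potent of the measured set, though only modestly so.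

Compound 4, `COc1cc2c(Oc3ccc(NC(=O)N/N=C/c4ccc(Cl)cc4Cl)cc3F)ccnc2cc1OCCCN1CCCCC1`, has not yet been measured. From compound 3 it differs by chloro in place of fluoro on an aromatic carbon. Among the measured compounds shown here, no measured step exchanges one halogen for another on this aromatic carbon, so none bears on the change directly. For the measured compounds named here, the closest precedent is a 1.1-fold higher number from compound 1 to compound 2 (0.05 log units; within the scatter), where one substituent was swapped for another and the number did not move beyond the scatter, whereas a 2.3-fold lower number from compound 1 to compound 3 (0.36 log units; beyond the scatter) and a 2.5-fold lower number from compound 2 to compound 3 (0.40 log units; beyond the scatter), which replaced the whole aryl group, moved the number modestly. The present change is smaller than either of those.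

Compound 4 is therefore expected to stay close to compound 3 in this assay, with an expected step of no change at the digits printed from compound 3 to compound 4 (within the scatter) that lies within the scatter. The estimated value for compound 4 is 260 nM, with a range from 120 nM to 560 nM.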

Compound 4, half-maximal inhibitory concentration: 370 nM
For compound 4 the middle estimate is 1.4-fold (0.15 log units) below the measured one, and the stated range covers the measured number.
By their numbers in this assay, from the lowest: compounds 3, 4, 1 and 2 (each within the scatter of the next, the first and the last beyond it).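

In this assay, putting chloro in place of fluoro on the aromatic carbon para to a large group and meta to a chloro group gives a 1.4-fold higher number from compound 3 to compound 4 (0.15 log units; within the scatter), so this position takes either halogen without a step beyond the scatter. The earlier compounds shown here did not show what this exchange does to the separation from the other aryl groups: compound 3 stood beyond the scatter from compound 1 and compound 2, whereas the 2,4-dichlorophenyl group gives a 1.8-fold lower number from compound 2 to compound 4 (0.25 log units; within the scatter) and a 1.6-fold lower number from compound 1 to compound 4 (0.20 log units; within the scatter), both within it. Nothing measured here accounts for this result.

The compounds shown leave open how a nitrile or an amine on this same carbon would read in this assay. They also leave open whether the exchange of the two halogens would read the same without the chloro group that stays in place.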